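The compounds below may be only part of what the source reports. "The series", "measured", "known", "first", "only" and "open" are said of these compounds alone.

Two compounds share one core. Compound 1 `Cc1cc(NC(=O)Cn2nnc(-c3ccc(Cl)c(Cl)c3)n2)n(C2CCCCC2)n1` gives 1220 nM in an assay on HEK293 cells for activation of Kir3.1/Kir3.2 (Homo sapiens), read by thallium flux (a lower number here means that less compound is needed, a higher number that more compound is needed for the effect), and compound 2 `Cc1cc(NC(=O)Cn2nnc(-c3cc(Cl)cc(Cl)c3)n2)n(C2CCCCC2)n1` gives 980 nM in this assay; the step of a 1.2-fold lower number from compound 1 to compound 2 (0.10 log units; within the scatter) shows that the two numbers cannot be told apart, so compound 2 stands level with compound 1. Compound 3 `Cc1cc(NC(=O)Cn2nnc(-c3ccc(F)c(F)c3)n2)n(C2CCCCC2)n1` differs from compound 2 by 3,4-difluorophenyl in place of 3,5-dichlorophenyl on an aromatic carbon. Among the compounds with values here, no measured step exchanges chlorine for fluorine, and the only measured step, which shifts the substituent pattern, stays within the scatter. The step expected in this assay is a 2.6-fold higher number from compound 2 to compound 3 (0.41 log units; beyond the scatter). Compound 3 is estimated at 2500 nM, with a range of 800 nM to 8000 nM.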

Compound 3, half-maximal effective concentration: 116 nM
Compound 3: the middle estimate sits 22-fold (1.33 log units) above what was measured; measured number below the stated range.
By their numbers in this assay, from the lowest: compound 3; then compounds 2 and 1 (each within the scatter of the next).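

On this aromatic carbon of the shared core, the identity of the halogen matters more than the earlier pattern swap suggested. In this assay, moving to 3,4-difluorophenyl gives an 8.4-fold lower number from compound 2 to compound 3 (0.93 log units; beyond the scatter) and also an 11-fold lower number from compound 1 to compound 3 (1.02 log units; beyond the scatter), and that second step keeps the substitution pattern and exchanges only chlorine for fluorine. Nothing available explains why the number falls. Still open, as far as these compounds go, is whether a phenyl ring carrying a single fluorine, a methoxy group or a nitrile would give a number as low as this one.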